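Swapping a hydroxy for an amino on the side chain

The source may report more compounds than this note shows. Statements on the series, on what has been measured and on what is new or still open speak of the compounds shown alone.

Measured so far:
Compound 1, `CCCCCCCCCO[C@@H]1[C@@H](N)[C@@H](OC[C@H](O)CN=[N+]=[N-])O[C@H](CN)[C@H]1OCCCCCCCCC`: 62.2%
Compound 2, `CCCCCCCCCO[C@@H]1[C@@H](N)[C@@H](OCC(O)CNCCO)O[C@H](CN)[C@H]1OCCCCCCCCC`: 99.1%

Both compounds share a core carrying two nonyl ether chains and differ only in the group on the side chain attached through oxygen. In a toxicity assay on the whole organism (J774 cells) for cytotoxicity, with Mus musculus as the target, read by MTT assay, with a stated time of 24 h, tested at 10 uM (on this read-out lower numbers stand for a stronger effect and higher numbers for a weaker effect at the one concentration tested), compound 1 gives 62.2%, and compound 2 gives 99.1%, the highest of the two numbers; the step of a number 36.9 percentage points higher from compound 1 to compound 2 (beyond the scatter) is large and lies beyond the scatter. A high number here means cells survive well, so compound 2 shows little effect.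

Compound 3, `CCCCCCCCCO[C@@H]1[C@@H](N)[C@@H](OCC(O)CNCCN)O[C@H](CN)[C@H]1OCCCCCCCCC`, has not yet been measured. It differs from compound 2 by amino in place of hydroxy on a saturated chain carbon, two bonds along the chain from an amine nitrogen. For the measured compounds named here, the only measured step, the one from compound 1 to compound 2, concerns a different exchange, an azide against a hydroxyethylamino group, so no measured step bears directly on this hydroxy-to-amino change. Given that compound 2 already sits near the top of the scale, the expectation is a step of a number 9.1 percentage points lower from compound 2 to compound 3 (within the scatter), most likely within the scatter or a modest downward shift. Compound 3 is estimated at 90%, within 70% to 105%.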

Compound 3, a percentage reported as activity, at one concentration (the size of the read-out at that concentration, not a potency): 87.5%
Compound 3: middle estimate off by 2.5 percentage points, on the high side; low and high end bracket the measured number.
By their numbers in this assay, from the lowest: compound 1; then compound 3; then compound 2.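

In this assay, exchanging hydroxy for amino is a swap of one heavy atom on a saturated chain carbon, two bonds along the chain from an amine nitrogen, and it gives a number 11.6 percentage points lower from compound 2 to compound 3 (beyond the scatter). Even so small an exchange registers at this place, and since lower numbers mean a stronger effect on the cells, the amino compound has the somewhat stronger effect of the two. Measured against the azide, the amino-bearing side chain gives a number 25.3 percentage points higher from compound 1 to compound 3 (beyond the scatter), so compound 3, like compound 2, has a weaker effect on the cells than compound 1, and the choice of group on the amine still shifts the number. Nothing measured here explains why amino and hydroxy differ at this place.

The compounds shown leave open how a dimethylamino group or a carboxylic acid at the same place would read, and whether a longer chain, such as 3-aminopropyl in place of 2-aminoethyl, would push the number further down. Going by these compounds, they also describe only one concentration, so how the effect changes with dose remains unknown.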